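The compounds below may be only part of what the source reports. "The series", "measured", "known", "first", "only" and "open" are said of these compounds alone.

Working notes on the series. The shared core of compound 2 `COc1ccc(/C=C/C(=O)c2cc(OC)c(OC)c(OC)c2)cc1OCCCC(=O)NCCCCN(CCCN)CCCCN` carries a polyamine tail on the amide; in a functional assay on HT-29 cells (Homo sapiens) for antiproliferative activity, read by MTT assay, with a stated time of 48 h (on this read-out higher numbers stand for weaker inhibition and lower numbers for stronger inhibition), compound 2 gives 74700 nM. Compound 3 `COc1cc(C(=O)/C=C/c2ccc(OCCCC(=O)NCCCNCCCCNCCN)cc2)cc(OC)c1OC`, the same tail on the other side of the enone, gives 98000 nM in this assay, a number within the usual scatter of that of compound 2. Compound 1 `COc1ccc(/C=C/C(=O)c2cc(OC)c(OC)c(OC)c2)cc1OCCCC(=O)NCCCNCCCCNCCN` reaches only the assay limit in this assay, > 100000 nM. Among the measured compounds shown here, the one measured step that touches the tail, an at least 1.3-fold lower number from compound 1 to compound 2 (0.12 log units; that floor lies within the scatter), rests on that limit of > 100000 nM in this assay, at which 1 of the 3 values shown sits, and says nothing beyond the scatter.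

Compound 4 `COc1ccc(/C=C/C(=O)c2cc(OC)c(OC)c(OC)c2)cc1OCCCC(=O)NCCCCNCCCN` is now to be measured in this assay. (hydrogen in place of 4-aminobutyl on an amine nitrogen). For the measured compounds named here, no measured step bears directly on this change; the only tail step in hand lies within the scatter, and no value of the series sits below the weak range. The step is therefore expected to be a 1.2-fold higher number from compound 2 to compound 4 (0.08 log units; within the scatter), a change not beyond the scatter in either direction. For compound 4 the expected value in this assay is 90000 nM, within a range of 30000 nM to 300000 nM.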

Compound 4, half-maximal inhibitory concentration: > 100000 nM
Compound 4 gave a limit, no number (the forecaster's own chance of this, stated with the estimate: 40%); middle value at least 1.1-fold (0.04 log units) away from the limit.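

Hydrogen in place of 4-aminobutyl on this amine nitrogen gives, in this assay, an at least 1.3-fold higher number from compound 2 to compound 4 (0.12 log units; that floor lies within the scatter). Among the compounds shown here, this is the first measured change at this nitrogen, and it shows only that removing the 4-aminobutyl group does not bring the number out of the weak range; its true size stays hidden, and the step between compound 1 and compound 4 cannot be read, since both values are limits. The read-out now has little room left for separating tails in this series: the limit of > 100000 nM in this assay, at which 2 of the 4 values shown sit.

Going by these compounds, it remains open whether any group on this amine nitrogen can move the number beyond the scatter, for example a longer aminoalkyl chain or a benzyl group. Also open, on these data alone, is how the shared core behaves with a carboxylic acid in place of the polyamine amide.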